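Chlorophenyl thioureas on the shared core: working notes

This account rests on a few compounds, and the source may have more. Where it says the series, first, only, none or still open, it means among the compounds named here.

Measured compounds:
compound 1 `COc1cc2c(cc1OC)C(=O)C(CC1CCN(C(=S)Nc3ccccc3Cl)CC1)C2` — 300 mg/kg
compound 2 `COc1cc2c(cc1OC)C(=O)C(CC1CCN(C(=S)Nc3cccc(Cl)c3)CC1)C2` — "not determined" (no result reported)
compound 3 `COc1cc2c(cc1OC)C(=O)C(CC1CCN(C(=S)Nc3ccc(Cl)cc3)CC1)C2` — to be measured

Among the compounds with values here, compound 2 stands nowhere on the numbers so far: in a functional assay on the whole organism (strain Swiss albino) with Mus musculus as the target, with a stated time of 4 h (a higher number here means that more compound is needed for the effect, a lower number that less compound is needed), compound 2 has no reported result, so no number is known for it. The only figure in the series belongs to compound 1, which in this assay gives 300 mg/kg; compound 1 carries a 2-chlorophenyl on the same amide-type nitrogen and is the sole anchor for the series.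

Compound 3 differs from compound 2 by 4-chlorophenyl in place of 3-chlorophenyl on an amide-type nitrogen. Within the data shown here, no step between two measured compounds that differ in one place exists, so the size of the step from compound 2 to compound 3 in this assay cannot be read from data. With compound 1 as the only reference, the expectation is a step no larger than the usual scatter, with no preferred direction, though the lack of any number for compound 2 leaves the chance that compound 3 also returns no usable figure.

Compound 3 is expected to give 300 mg/kg, within a range of 100 mg/kg to 1000 mg/kg.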

Compound 3, minimum effective dose: 300 mg/kg
Compound 3: the middle estimate sits on the measured number at the digits printed, and the stated range covers the measured number.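

In this assay the series gains its first readable step: no change at the digits printed from compound 1 to compound 3 (within the scatter) accompanies 4-chlorophenyl in place of 2-chlorophenyl on the amide-type nitrogen whose other neighbour is the thiocarbonyl carbon. For these two compounds, the minimum effective dose therefore does not separate the two chlorophenyl groups, which a single value could not show; the steps involving compound 2 cannot be read, as compound 2 has no reported result. No measured evidence accounts for this result.

The compounds shown leave open where 3-chlorophenyl would stand relative to the other two chlorophenyl groups, and so whether the lack of separation extends to all three. They also leave open whether the minimum effective dose stays the same when the chlorophenyl on this nitrogen gives way to something other than a chlorophenyl, such as an unsubstituted phenyl, a methoxyphenyl, a benzyl group or a longer alkyl chain.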